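Shortening an Ether Side Chain to a Primary Amine

The source may hold more compounds than are shown below. What is called first, only, known or untested is meant among the compounds shown, and "the series" means these compounds.

Compound 1 `c1cc([C@H]2CC[C@]3(CC2)OOC2(O3)C3CC4CC(C3)CC2C4)ccc1OCCOC1CCNCC1` was tested in an ADME assay on the whole organism (strain FVB) for pharmacokinetics, with Mus musculus as the target, read by LC-MS, at a dose of 30 mg/kg by the oral route (on this read-out lower numbers stand for lower exposure and higher numbers for higher exposure at the dose given), and gave 633 nM, the highest of the two numbers recorded, although its nearest neighbour sits within the scatter. That neighbour, compound 2 `CC(C)(CN)Oc1ccc([C@H]2CC[C@]3(CC2)OOC2(O3)C3CC4CC(C3)CC2C4)cc1`, reached 529 nM in this assay. Within the data shown here, the only measured step, a 1.2-fold lower number from compound 1 to compound 2 (0.08 log units; within the scatter), replaced the piperidinyl ether chain with a short primary amine and changed nothing beyond the scatter.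

Compound 3 `NCCCCOc1ccc([C@H]2CC[C@]3(CC2)OOC2(O3)C3CC4CC(C3)CC2C4)cc1` differs from compound 1 by a related change: 2-aminoethyl in place of (piperidin-4-yl)oxy on a saturated chain carbon, two bonds along the chain from an oxygen on an aromatic ring. Like compound 2, it carries a primary amine on an open chain in place of the ring-bearing ether. Since the step from compound 1 to compound 2 was within the scatter, the step expected here, a 1.1-fold lower number from compound 1 to compound 3 (0.05 log units; within the scatter), is likewise estimated to stay within it. Compound 3 is therefore expected to give about 560 nM, with a range of 250 nM to 1300 nM.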

Compound 3, maximal plasma concentration: 370 nM
Estimate against measurement, compound 3: 1.5-fold (0.18 log units) above; the measured number falls inside the stated range.
By their numbers in this assay, from the lowest: compounds 3, 2 and 1 (each within the scatter of the next).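

In this assay, putting 4-aminobutyl in place of 2-((piperidin-4-yl)oxy)ethyl on the oxygen gives a 1.7-fold lower number from compound 1 to compound 3 (0.23 log units; within the scatter) and so removes the ring and the ether oxygen from the chain without leaving the scatter. Replacing the branched 1-(aminomethyl)-1-methylethyl with the straight 4-aminobutyl on that same oxygen gives a 1.4-fold lower number from compound 2 to compound 3 (0.16 log units; within the scatter), so the ring-bearing, branched and straight chains cannot be told apart on this read-out. Nothing available gives a reason for this result.

From the compounds shown here alone, it remains open whether the amine itself matters, for instance whether a carboxylic acid in its place would stay within the same range. Also open, going by these compounds, is how a shorter chain such as 2-aminoethyl, or a dimethylamino group in place of the primary amine, would compare.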